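A few compounds are considered here, and "the series" means these few. Any claim that something is new, unique, unknown or untested is made for them only; others in the source may bear on it.

Measured compounds in a functional assay on RBL-2H3 cells (Rattus norvegicus) for inhibition; on this read-out lower numbers stand for stronger inhibition and higher numbers for weaker inhibition:
compound 1 `Cc1csc(N/C(S)=N/[C@@H](C)c2cccc3ccccc23)n1` gives 83200 nM.
compound 2 `Cc1cccc(N/C(S)=N/[C@@H](C)c2cccc3ccccc23)n1` gives 1600 nM.
compound 3 `Cc1ccc(N/C(S)=N/[C@@H](C)c2cccc3ccccc23)nc1` gives only a limit of the assay, > 100000 nM.

Compound 3 thus stands at the weak end of the three, with a limit and no number; the step of an at least 62-fold higher number from compound 2 to compound 3 (1.79 log units; beyond the scatter) is large, whereas the step of an at least 1.2-fold higher number from compound 1 to compound 3 (0.07 log units; that floor lies within the scatter) sits within the scatter at its floor, see (the limit of > 100000 nM in this assay, at which 1 of the 3 values shown sits). Compound 4 `C[C@H](/N=C(\S)Nc1nccs1)c1cccc2ccccc12` is not yet measured and differs from compound 3 as follows: 1,3-thiazol-2-yl in place of 5-methylpyridin-2-yl on an amine nitrogen. The step that bears on this change is an at least 1.2-fold higher number from compound 1 to compound 3 (0.07 log units; that floor lies within the scatter), which carries 4-methyl-1,3-thiazol-2-yl to 5-methylpyridin-2-yl without a change beyond the scatter; going back toward a thiazole is therefore expected to give a number near that of compound 1 rather than near compound 2. For compound 4 in this assay the step of an at least 1.2-fold lower number from compound 3 to compound 4 (0.09 log units; that floor lies within the scatter) is expected, giving an estimate of 80000 nM with a range from 20000 nM to 300000 nM; a limit instead of a number remains quite possible.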

Compound 4, half-maximal inhibitory concentration: > 100000 nM
Compound 4: a limit, no number (the forecaster's own chance of this, stated with the estimate: 40%); middle value at least 1.2-fold (0.09 log units) from the limit.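

In this assay compound 4 gives > 100000 nM, a limit and not a number. Hydrogen in place of methyl on the thiazole brings no measurable recovery, with an at least 1.2-fold higher number from compound 1 to compound 4 (0.07 log units; that floor lies within the scatter), while the gap to the 6-methylpyridin-2-yl group stays large, with an at least 62-fold higher number from compound 2 to compound 4 (1.79 log units; beyond the scatter), so the unsubstituted 1,3-thiazol-2-yl on the amine nitrogen joins 5-methylpyridin-2-yl at the weak end. The step between compound 3 and compound 4 cannot be read, both values being limits of the assay: the limit of > 100000 nM in this assay, at which 2 of the 4 values shown sit.

From the compounds shown here alone, how far compound 3 and compound 4 lie past that limit stays open, and the floor of the step to compound 4 leaves the true effect of the methyl unknown. Also open, going by these compounds, is whether an unsubstituted pyridin-2-yl or a 6-aminopyridin-2-yl would keep the activity of compound 2, at 1600 nM.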